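A few compounds are considered here, and "the series" means these few. Any claim that something is new, unique, unknown or untested is made for them only; others in the source may bear on it.

Measured compounds:

Compound 1 `Cc1cc(=O)c(O)c(C)o1` — in an ADME assay for lipophilicity (a higher number here means a more lipophilic compound, a lower number a more polar compound), compound 1 gives 0.44.
Compound 2 `CCCc1oc(C)cc(=O)c1O` — in this assay compound 2 gives 1.4.
Compound 3 `CCCCn1ccc(=O)c(O)c1C` — in this assay compound 3 gives 0.71.

Compound 1 and compound 2 share a core and differ by ethyl in place of hydrogen on a saturated chain carbon bound to an aromatic carbon. That change gives a number 0.96 log units higher from compound 1 to compound 2 (beyond the scatter) in this assay.

Compound 3 sits on a different core; the difference between the two cores is not broken down here. Its value lies close to that of compound 1 and below that of compound 2.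

Compound 4 `CCCCCCn1ccc(=O)c(O)c1C` is not yet measured in this assay. It differs from compound 3 by ethyl in place of hydrogen on a saturated chain carbon, four bonds along the chain from an aromatic nitrogen. Among the measured compounds shown here, the change is the same kind of change as the one from compound 1 to compound 2, the same hydrogen-to-ethyl exchange on a saturated chain carbon, but the place is not identical: in compound 1 the carbon is bound to an aromatic carbon, whereas in compound 3 it lies four bonds along the chain from an aromatic nitrogen.

For the measured compounds named here, the only measured precedent is the step from compound 1 to compound 2. Resting on a number 0.96 log units higher from compound 1 to compound 2 (beyond the scatter), a step of about the same size is expected for the chain extension on the core of compound 3, since the same two carbons enter in both cases. For compound 4 the expected step is a number 0.94 log units higher from compound 3 to compound 4 (beyond the scatter) in this assay. The estimated value for compound 4 is 1.65. Given that only one precedent exists and the place differs, the estimate for compound 4 is expected to fall between 1.3 and 2.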

Compound 4, distribution coefficient: 1.9
Estimate against measurement, compound 4: 0.25 log units below; the range from low to high includes it.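

Ethyl in place of hydrogen on a saturated chain carbon, four bonds along the chain from an aromatic nitrogen, gives a number 1.19 log units higher from compound 3 to compound 4 (beyond the scatter) in this assay. Set beside the earlier step, the change carries from the core of compound 1 to the core of compound 3 with no difference in size that can be told apart: the same change on two cores in this assay, a number 0.96 log units higher (beyond the scatter) from compound 1 to compound 2 and a number 1.19 log units higher (beyond the scatter) from compound 3 to compound 4, 0.23 log units apart, within the scatter of two such steps. This agreement rests on a single pair on each core, with the change in a different place on each, and it does not show that a step of this size would hold on a further core, with a different entering group, or at another place on the chain.

The compounds shown carry only plain saturated chains at the changed place, which leaves open whether a longer chain would continue the same upward run in this assay on either core. Also open, from the compounds shown here alone, is how an amine, a carboxylic acid or a ring on the chain would compare with ethyl, and whether such a group would give steps that match between the two cores as these two do.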